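Biphenyl phenols and cytotoxicity in a lung carcinoma line

The compounds below may be only part of what the source reports. "The series", "measured", "known", "first", "only" and "open" are said of these compounds alone.

Three compounds of this series were assessed in a functional assay on A549 cells (Homo sapiens) for cytotoxicity, read by sulforhodamine B assay; on this read-out higher numbers stand for weaker inhibition and lower numbers for stronger inhibition. Compound 1 `COc1cc(-c2ccccc2)cc(O)c1O` reaches only the limit of the assay, giving > 10000 nM. Compound 2 `COc1cc(O)cc(-c2ccccc2)c1` likewise sits at the limit, with > 10000 nM. Compound 3 `COc1cc(OC)cc(-c2ccccc2)c1` also returns a limit, > 10000 nM. The two limits leave a step that the two limits leave unreadable from compound 2 to compound 1 unreadable, a change of hydroxy in place of hydrogen on an aromatic carbon, and the same holds for a step that the two limits leave unreadable from compound 2 to compound 3, a change of methyl in place of hydrogen on an oxygen on an aromatic ring, so that the limit of > 10000 nM in this assay, at which 3 of the 3 values shown sit, sums up everything known. Compound 4 `COc1cc(OC)cc(-c2ccc(O)cc2)c1` awaits measurement. It differs from compound 3 by hydroxy in place of hydrogen on an aromatic carbon, the same kind of change as from compound 2 to compound 1, though there the place was ortho to a hydroxy group, ortho to a methoxy group and para to a group of 6 heavy atoms, whereas here it is para to a large group; the two cores differ by methyl in place of hydrogen on an oxygen on an aromatic ring. With every value at the limit, the step from compound 3 to compound 4 is expected to be a step that the limit leaves unreadable from compound 3 to compound 4, and compound 4 is estimated at 15000 nM in this assay, ranging from 5000 nM to 50000 nM.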

Compound 4, half-maximal inhibitory concentration: > 10000 nM
Compound 4 was reported as a limit (the forecaster's own chance of this, stated with the estimate: 80%); the middle value lies beyond the limit too.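

No step can be read from compound 3 to compound 4, as both values are limits, and what is known remains: the limit of > 10000 nM in this assay, at which 4 of the 4 values shown sit.

The compounds shown leave open how strongly any of them acts in this assay, and whether any of these changes alters that.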